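Swapping 4-Carboxyphenyl for Isopropyl in Compound 1

The source may report more compounds than this note shows. Statements on the series, on what has been measured and on what is new or still open speak of the compounds shown alone.

In a functional assay on RAW264.7 cells (Mus musculus) for inhibition, read by Griess assay, with stated times of 1 h and 24 h (a higher number here means a weaker inhibitor, a lower number a stronger inhibitor), compound 1 (`CCCc1nn(C)c2c(Nc3ccc(C(=O)O)cc3)nc(-c3cc(OC)c(OC)c(OC)c3)nc12`) gives 15800 nM, the higher of the two numbers available. Compound 3 (`CCCc1nn(C)c2c(NC(C)C)nc(/C=C/c3cc(OC)c(OC)c(OC)c3)nc12`) gives 3170 nM, clearly lower, while compound 2 (`CCCc1nn(C)c2c(Nc3ccccc3)nc(/C=C/c3ccccc3)nc12`) is reported as "not active" (no number reported), with no number. Compound 4 (`CCCc1nn(C)c2c(NC(C)C)nc(-c3cc(OC)c(OC)c(OC)c3)nc12`) is still unmeasured. It differs from compound 1 in one place: isopropyl sits in place of 4-carboxyphenyl on a nitrogen on an aromatic ring (isopropyl in place of 4-carboxyphenyl on a nitrogen on an aromatic ring). Compound 3 also carries isopropylamino and gives 3170 nM, so a lower number seems likely. In this assay, a moderate drop is expected, a 3.2-fold lower number from compound 1 to compound 4 (0.50 log units; beyond the scatter). For compound 4 the estimated value is 5000 nM, with an expected range of 1500 nM to 16000 nM.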

Compound 4, half-maximal inhibitory concentration: 10800 nM
The estimate for compound 4 lay 2.2-fold (0.33 log units) below the measured number; the measured number falls inside the stated range.
By their numbers in this assay, from the lowest: compound 3; then compounds 4 and 1 (each within the scatter of the next).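

In this assay, isopropyl in place of 4-carboxyphenyl on this nitrogen gives a 1.5-fold lower number from compound 1 to compound 4 (0.17 log units; within the scatter), a step within the scatter. On the core of compound 1, then, the aromatic ring and the carboxylic acid can both go without a change that this assay can tell from repeat-measurement scatter. This position accepts two very different groups, at least on this core.

As far as these compounds go, what a benzyl group or a longer chain such as butyl would give on this nitrogen stays open. No measurement shown offers an explanation for this result.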